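The source may hold more compounds than are shown below. What is called first, only, known or untested is meant among the compounds shown, and "the series" means these compounds.

Measured so far:
compound 1 `S=C(N/N=C\c1ccnc2ccccc12)Nc1cccnc1` — 970 nM
compound 2 `S=C(N/N=C\c1ccnc2ccccc12)Nc1ccc(Br)cc1` — 990 nM

In a functional assay on MCF7 cells (Homo sapiens) for cytotoxicity, read by MTT assay, with a stated time of 48 h (on this read-out higher numbers stand for weaker inhibition and lower numbers for stronger inhibition), compound 2 stands at the higher of the two numbers, though the step of a 1.0-fold higher number from compound 1 to compound 2 (0.01 log units; within the scatter) lies within the scatter, so the two compounds cannot be told apart. Compound 3 `S=C(N/N=C\c1ccnc2ccccc12)Nc1ccc(Cl)cc1` carries the change (chloro in place of bromo on an aromatic carbon). For the measured compounds named here, no measured step shows a halogen swap; the one step that exists, from compound 1 to compound 2, replaced a whole ring and gave no shift. A step of no more than the scatter is therefore expected in this assay, in no particular direction, as a 1.0-fold higher number from compound 2 to compound 3 (0.00 log units; within the scatter). Compound 3 is estimated at 1000 nM (range 500 nM to 2000 nM).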

Compound 3, half-maximal inhibitory concentration: 1070 nM
Estimate against measurement, compound 3: 1.1-fold (0.03 log units) below; low and high end bracket the measured number.
By their numbers in this assay, from the lowest: compounds 1, 2 and 3 (each within the scatter of the next).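

In this assay chloro in place of bromo on the aromatic carbon gives a 1.1-fold higher number from compound 2 to compound 3 (0.03 log units; within the scatter) and so does not separate the two halogens at this position. The ring change read with chloro gives a 1.1-fold higher number from compound 1 to compound 3 (0.04 log units; within the scatter) and so 4-chlorophenyl, like 4-bromophenyl, cannot be told apart from pyridin-3-yl on the amide-type nitrogen. No evidence bears on these results. On these data alone, whether an amine or a carboxylic acid on this aromatic carbon would shift the number beyond the scatter stays open. The compounds shown also leave open any change to the shared core.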